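This account rests on a few compounds, and the source may have more. Where it says the series, first, only, none or still open, it means among the compounds named here.

Compound 3 `CCN(c1ccc(C#N)c(Cl)c1)c1cc(-c2ccncc2)ccc1C` is one of three related compounds built on a shared core. Compound 1 `CCN(c1ccc(C#N)c(Cl)c1)c1cc(-c2ccoc2)ccc1C` carries a furan-3-yl group on that core, but in an ADME assay on L02 cells (Homo sapiens) for antiproliferative activity, read by CCK-8 assay, with a stated time of 6 days (on this read-out higher numbers stand for weaker inhibition and lower numbers for stronger inhibition), the result for compound 1 is "not determined" (no result reported). Compound 2 `CCN(c1ccc(C#N)c(Cl)c1)c1cc(-c2c[nH]nc2C)ccc1C` carries a 3-methyl-1H-pyrazol-4-yl group and in this assay compound 2 gives 5780 nM. Compound 3 carries pyridin-4-yl and in this assay compound 3 gives 1730 nM, the lowest of the two numbers available. For the measured compounds named here, the one step that has been measured, a 3.3-fold lower number from compound 2 to compound 3 (0.52 log units; beyond the scatter), shows that exchanging the methylpyrazole for the pyridine moved the number beyond the scatter.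

Compound 4 `CCN(c1ccc(C#N)c(Cl)c1)c1cc(-c2ccnn2C)ccc1C` differs from compound 3 in one place: 1-methyl-1H-pyrazol-5-yl in place of pyridin-4-yl on an aromatic carbon. This change returns a methylpyrazole to the same aromatic carbon, so the measured step bears on it in reverse. It is therefore expected that the number rises again, and compound 4 is estimated at 4000 nM in this assay, within 1500 nM to 12000 nM, which would mean a step of a 2.3-fold higher number from compound 3 to compound 4 (0.36 log units; beyond the scatter).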

Compound 4, half-maximal inhibitory concentration: 6230 nM
The estimate for compound 4 lay 1.6-fold (0.19 log units) below the measured number, within the range that was stated.
By their numbers in this assay, from the lowest: compound 3; then compounds 2 and 4 (each within the scatter of the next).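

In this assay, replacing pyridin-4-yl with 1-methyl-1H-pyrazol-5-yl gives a 3.6-fold higher number from compound 3 to compound 4 (0.56 log units; beyond the scatter), so the earlier step is now matched by a second methylpyrazole on this aromatic carbon. The two methylpyrazoles cannot be told apart, with a 1.1-fold higher number from compound 2 to compound 4 (0.03 log units; within the scatter), so among the compounds with a number, the six-membered aromatic ring of compound 3 stands apart from both five-membered aromatic rings, and the arrangement of the methyl group and ring nitrogens in those two pyrazoles shows no effect beyond the scatter. Nothing available explains this difference.

As far as these compounds go, whether the lower number belongs to pyridin-4-yl alone or extends to other six-membered aromatic rings remains open. A phenyl ring, pyridin-3-yl or a pyridine bearing an amine could test this at the same aromatic carbon.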